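A few compounds are considered here, and "the series" means these few. Any claim that something is new, unique, unknown or untested is made for them only; others in the source may bear on it.

In a functional assay on HL-60 cells (Homo sapiens) for antiproliferative activity, with a stated time of 72 h (a higher number here means a weaker inhibitor, a lower number a stronger inhibitor), compound 1 (`Nc1ncnn2c([C@@H]3O[C@H](CO)[C@@H](O)[C@H]3O)cc(C#Cc3ccc(F)cc3)c12`) gives only a limit, > 100000 nM. Going by the values given here, compound 2 (`Nc1ncnn2c([C@@H]3O[C@H](CO)[C@@H](O)[C@H]3O)cc(-c3ccsc3)c12`) gives 37300 nM, the only actual number so far. Compound 3 (`Nc1ncnn2c([C@@H]3O[C@H](CO)[C@@H](O)[C@H]3O)cc(-c3ccccc3Cl)c12`) has yet to be measured. It carries 2-chlorophenyl in place of thiophen-3-yl on an aromatic carbon of the five-membered aromatic ring with 1 nitrogen: 2-chlorophenyl in place of thiophen-3-yl on an aromatic carbon.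

Among the compounds with values here, the one measured step that bears on this change is an at least 2.6-fold lower number from compound 1 to compound 2 (0.42 log units; beyond the scatter). From the compounds shown here alone, it falls on the same aromatic carbon and shows that the group there can move the number, though its full size remains open. Within the data shown here, no step between two directly attached aromatic rings has been measured, so no large shift is expected in this assay. A small move toward a higher number is the likeliest outcome, and it would stay within the scatter. The expected step is a 1.3-fold higher number from compound 2 to compound 3 (0.13 log units; within the scatter). For compound 3, the estimated value is 50000 nM, with an expected range from 18000 nM to 100000 nM.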

Compound 3, half-maximal inhibitory concentration: > 100000 nM
Compound 3: only a limit was reported; the forecaster's own chance of this, stated with the estimate: 35%; middle value at least 2.0-fold (0.30 log units) from the limit.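

The group on this aromatic carbon of the shared core can now be seen to move the number in both directions in this assay: replacing thiophen-3-yl with 2-chlorophenyl gives an at least 2.6-fold higher number from compound 2 to compound 3 (0.42 log units; beyond the scatter), the opposite direction to an at least 2.6-fold lower number from compound 1 to compound 2 (0.42 log units; beyond the scatter). Two directly attached aromatic rings therefore do not read alike at this position, so having such a ring here is not enough on its own to give a readable number. The step between compound 1 and compound 3 cannot be read, and the step to compound 3 has a known minimum but no known full size, because of this: the limit of > 100000 nM in this assay, at which 2 of the 3 values shown sit.

The compounds shown leave open whether the rise goes with the chlorine or with the six-membered ring itself, which a phenyl group without the chlorine would help to separate. They also leave open how a small group of another kind on this carbon, such as an amine or a hydroxymethyl group, would read in this assay.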